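The source may report more compounds than this note shows. Statements on the series, on what has been measured and on what is new or still open speak of the compounds shown alone.

Measured in an ADME assay on L1210/0 cells (Mus musculus) for cytotoxicity, with a stated time of 48 h; a higher number here means a weaker inhibitor, a lower number a stronger inhibitor:
- Compound 1 `O[C@H]1C[C@@H](Cn2cnc3c(Cl)ncnc32)c2ccccc21`: > 200000 nM (a limit)
- Compound 2 `Nc1ncnc2c1nnn2C1C[C@H](CO)[C@@H](CO)[C@@H]1CO`: > 200000 nM (a limit)
- Compound 3 `O=C1O/C(=C\Cn2cc(F)c(=O)[nH]c2=O)C(OCc2ccccc2)=C1OCc1ccccc1`: 5100 nM

Compound 2 reads > 200000 nM in this assay, which is a limit and not a number. Compound 2 stands at the limit of > 200000 nM in this assay, at which 2 of the 3 values shown sit. Compound 3, of a different structure, is the only one of the three with a number, 5100 nM.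

Compound 4 `Nc1ncnc2c1nnn2[C@@H]1C[C@H](CO)[C@@H](CO)[C@H]1CO` differs from compound 2 only in its drawn stereochemistry: the two compounds have the same atoms and bonds; at least one stereo element is drawn with a configuration in one of them and without one in the other: 2 of 4 stereo elements differ; a stereocentre at a saturated ring carbon is drawn without a configuration in compound 2 and R in compound 4; a stereocentre at a saturated ring carbon is drawn S in compound 2 and R in compound 4. The two compounds have the same atoms and bonds. A stereocentre at a saturated ring carbon drawn without a configuration in compound 2 is R in compound 4, and another drawn S in compound 2 is R in compound 4.

Among the compounds with values here, no measured pair shows what such a change does in this assay. No step beyond the scatter is expected in either direction, and the expected change is a number no higher from compound 2 to compound 4 (the limit leaves the size open). This expectation rests on the limit of compound 2, > 200000 nM. Compound 4 is estimated at 200000 nM, with an expected range from 100000 nM to 400000 nM.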

Compound 4, half-maximal inhibitory concentration: > 200000 nM
Compound 4 ended at the assay's limit; the forecaster's own chance of this, stated with the estimate: 80%; the middle value sits exactly at the limit.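

Compound 4 reads > 200000 nM in this assay, which is a limit and not a number. Compound 2 also sits at a limit, so no step between the two can be read: the limit of > 200000 nM in this assay, at which 3 of the 4 values shown sit.

From the compounds shown here alone, whether the stereochemistry separating compound 2 and compound 4 affects the read-out in this assay stays open.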